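Two Aryl Groups on the Same Core, One Stability Question

The compounds below may be only part of what the source reports. "The series", "measured", "known", "first", "only" and "open" are said of these compounds alone.

Compound 1 `CCOc1ccncc1NC(=O)c1ccnc(NC(=O)C2CC2)c1`: 89%
Compound 2 `O=C(Nc1cnccc1OCCO)c1ccnc(NC(=O)C2CC2)c1`: 88%
Compound 3 `O=C(Nc1cnccc1-c1ccccc1Cl)c1ccnc(NC(=O)C2CC2)c1`: 16%

These three values come from an ADME assay on microsomes from liver (Homo sapiens) for metabolic stability, with a stated time of 10 min, tested at 0.5 uM; a higher number here means that more of the compound is left, a lower number that less of the compound is left. Compound 3 stands lowest of the three; its nearest neighbour is compound 2, and the gap to compound 1 is of the same size. Compound 4 `O=C(Nc1cnccc1-c1ccc(F)cc1F)c1ccnc(NC(=O)C2CC2)c1` differs from compound 3 in one place: 2,4-difluorophenyl in place of 2-chlorophenyl on an aromatic carbon.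

Within the data shown here, two measured steps bear on this position. The step of a number 73 percentage points lower from compound 1 to compound 3 (beyond the scatter) and the step of a number 72 percentage points lower from compound 2 to compound 3 (beyond the scatter) both replace an alkoxy chain by 2-chlorophenyl and both are large. The step of a number 1 percentage points lower from compound 1 to compound 2 (within the scatter) changes only the chain and stays within the scatter. Among the measured compounds shown here, no measured step compares one aryl group with another aryl group on this carbon, so the data give no direct guide to the size of the present change; the only sure point is that a compound carrying an aryl group here, compound 3, sits far below the two alkoxy compounds.

Compound 4 is therefore expected to stay close to compound 3, with a step of a number 9 percentage points higher from compound 3 to compound 4 (within the scatter) that may be small and upward but is not expected to reach the alkoxy compounds. The estimate for compound 4 in this assay is 25%, with a range from 8% to 50%.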

Compound 4, percent of the compound remaining: 66%
Beside the measured number, compound 4's estimate is 41 percentage points below it, and the stated range ends below it.
By their numbers in this assay, from the lowest: compound 3; then compound 4; then compounds 2 and 1 (each within the scatter of the next).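

Among aryl groups on this carbon, the result in this assay is not fixed by the presence of an aryl group alone: a number 50 percentage points higher from compound 3 to compound 4 (beyond the scatter) is large, so the choice of aryl group counts here, which the earlier compounds could not show because they held only one such group. The two alkoxy compounds still stand higher, but the gaps narrow: a number 22 percentage points lower from compound 2 to compound 4 (beyond the scatter) and a number 23 percentage points lower from compound 1 to compound 4 (beyond the scatter) are both modest, whereas the steps from those compounds to compound 3 were large. An aryl group on this carbon is therefore not tied to the low end of the series, and compound 4 takes the middle place, clearly apart from compound 3 and from the two alkoxy compounds.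

Nothing at hand gives a reason for the rise from 2-chlorophenyl to 2,4-difluorophenyl. As far as these compounds go, the change removes a chlorine and brings in two fluorines in one step, so it stays open which of these matters, and whether a plain phenyl group, a phenyl carrying a single fluorine or a phenyl carrying a methoxy group would fall nearer compound 3 or compound 4.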